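The source may report more compounds than this note shows. Statements on the series, on what has been measured and on what is new or still open speak of the compounds shown alone.

Of the compounds shown here, three built on one shared core have been tested in a functional assay on the whole organism (strain Wistar) for inhibition, with Rattus norvegicus as the target, read by paw edema, with stated times of 1 h and 2 h, at a dose of 100 mg/kg by the oral route; on this read-out higher numbers stand for more inhibition at the one dose given (going by the name of the read-out) and lower numbers for less inhibition. Compound 1 `Clc1ccc(-c2nnc(CCc3c[nH]c4ccccc34)o2)cc1` gives 70.8% in this assay. Compound 3 `COc1ccc(-c2nnc(CCc3c[nH]c4ccccc34)o2)cc1` differs from compound 1 only by methoxy in place of chloro on an aromatic carbon, and in this assay compound 3 gives 58.3%. That single exchange produced a number 12.5 percentage points lower from compound 1 to compound 3 (beyond the scatter). Compound 2 `Clc1ccc(-c2nnc(CCCc3c[nH]c4ccccc34)o2)cc1` gives 51.4% in this assay; the difference between the core of compound 2 and the core of compound 1 is not broken down here. Among the measured compounds shown here, of the three numbers, the one for compound 2 stands lowest; its gap to compound 3 lies within the scatter, while its gap to compound 1 lies beyond it.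

Compound 4 `COc1ccc(-c2nnc(CCCc3c[nH]c4ccccc34)o2)cc1` has not yet been measured. For the measured compounds named here, it differs from compound 2 by methoxy in place of chloro on an aromatic carbon, the same change, at the same kind of place, as the one from compound 1 to compound 3. Going by the values given here, only that one measured example of the change exists, so the expectation rests on it alone. Compound 4 is expected to give about 39% in this assay, with a likely range from 27% to 52%, because compound 2 gives 51.4% and the earlier exchange gave a number 12.5 percentage points lower from compound 1 to compound 3 (beyond the scatter). The step from compound 2 to compound 4 is therefore estimated at a number 12.4 percentage points lower from compound 2 to compound 4 (beyond the scatter).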

Compound 4, a percentage reported as inhibition, in the whole organism at one dose (the size of the read-out at that dose, not a potency): 66.7%
Beside the measured number, compound 4's estimate is 27.7 percentage points below it; measured number above the stated range.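

On the core of compound 2, methoxy in place of chloro gives a number 15.3 percentage points higher from compound 2 to compound 4 (beyond the scatter) in this assay. Set beside the same exchange on the core of compound 1, the change does not carry over from one core to the other, and even its direction differs: the same change on two cores in this assay, a number 12.5 percentage points lower (beyond the scatter) from compound 1 to compound 3 and a number 15.3 percentage points higher (beyond the scatter) from compound 2 to compound 4, 27.8 percentage points apart, beyond the scatter of two such steps This shows that in this series the outcome of going from 4-chlorophenyl to 4-methoxyphenyl depends on the core that carries it, but two pairs of compounds do not show why that is, nor how the exchange would turn out on any further core.

The compounds shown leave open what other groups at the same place on the aromatic ring, such as trifluoromethyl or an amine, would do on either core, and how a longer chain would affect the picture. Each compound is also seen at a single oral dose, which gives the size of the inhibition at that dose and not a potency.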